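The compounds below may be only part of what the source reports. "The series", "measured", "known", "first", "only" and "open" are said of these compounds alone.

Measured so far in an ADME assay (liver) for metabolic stability, with Liver microsome (Rattus norvegicus) as the target, using microsomes and NADPH, with a stated time of 30 min, tested at 1 uM; on this read-out higher numbers stand for fast clearance and lower numbers for slow clearance:
compound 1 `Nc1ccc(S(=O)(=O)N2CCN(c3ncc(C(O)(C(F)(F)F)C(F)(F)F)cc3C#CCO)CC2)cn1`: 65 mL.min-1.g-1
compound 2 `Cn1cc(-c2cc(C(O)(C(F)(F)F)C(F)(F)F)cnc2N2CCN(S(=O)(=O)c3ccc(N)nc3)CC2)cn1`: 44 mL.min-1.g-1
compound 3 `NC(=O)c1cccc(-c2cc(C(O)(C(F)(F)F)C(F)(F)F)cnc2N2CCN(S(=O)(=O)c3ccc(N)nc3)CC2)c1`: 63 mL.min-1.g-1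

These three compounds share one core and differ only in the group on a single aromatic carbon. Compound 3, at 63 mL.min-1.g-1, stands within the scatter of both other compounds. The measured steps that reach it are a 1.0-fold lower number from compound 1 to compound 3 (0.01 log units; within the scatter) and a 1.4-fold higher number from compound 2 to compound 3 (0.16 log units; within the scatter). The remaining comparison, a 1.5-fold lower number from compound 1 to compound 2 (0.17 log units; within the scatter), is also small. In this assay, then, none of these three groups sets its compound apart from the others.

Compound 4 `COc1ccc(-c2cc(C(O)(C(F)(F)F)C(F)(F)F)cnc2N2CCN(S(=O)(=O)c3ccc(N)nc3)CC2)cn1` has not yet been measured. It carries 6-methoxypyridin-3-yl in place of 3-carbamoylphenyl on an aromatic carbon. Going by the values given here, no measured compound holds this new group, so the expectation can only lean on the steps already seen at this same place. The closest of them is a 1.4-fold higher number from compound 2 to compound 3 (0.16 log units; within the scatter), which also exchanges one aromatic group for another. Three compounds are a thin basis, so the range has to stay wide. The expected step is a 1.1-fold lower number from compound 3 to compound 4 (0.06 log units; within the scatter), which means no change beyond the scatter. For compound 4 the estimated value is 55 mL.min-1.g-1, with an expected range from 32 mL.min-1.g-1 to 95 mL.min-1.g-1.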

Compound 4, intrinsic clearance in microsomes: 265 mL.min-1.g-1
For compound 4 the middle estimate is 4.8-fold (0.68 log units) below the measured one; the measured number lies above the stated range.
By their numbers in this assay, from the lowest: compounds 2, 3 and 1 (each within the scatter of the next); then compound 4.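

In this assay, this aromatic carbon had looked indifferent to what it carried, but the change to 6-methoxypyridin-3-yl gives a step beyond the scatter (a 4.2-fold higher number from compound 3 to compound 4 (0.62 log units; beyond the scatter)). The comparisons with the other two groups point the same way (a 6.0-fold higher number from compound 2 to compound 4 (0.78 log units; beyond the scatter); a 4.1-fold higher number from compound 1 to compound 4 (0.61 log units; beyond the scatter)), so compound 4 stands clear of all three earlier compounds, and the group at this place can make a real difference to clearance even though three quite different groups had given numbers within the scatter of one another. Nothing available here explains why this one group stands apart from the rest.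

Still open, from the compounds shown here alone, is whether the higher number goes with the methoxy group, with the ring nitrogen or only with the two together, which a plain pyridin-3-yl group and a 4-methoxyphenyl group at the same carbon could help to separate. Also open, going by these compounds, is how far the effect reaches among other groups at this carbon, such as an ethoxy group on the same pyridine ring or a simple amine in place of the ring.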